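A few compounds are considered here, and "the series" means these few. Any claim that something is new, unique, unknown or untested is made for them only; others in the source may bear on it.

The series shares one core, carrying an amide whose aryl part varies. Compound 2 `O=C(/C=C/c1cccc(NC(=O)c2ccccc2Br)c1)c1nc2ccccc2[nH]1` gives 4520 nM in a functional assay on MCF7 cells (Homo sapiens) for antiproliferative activity, read by MTT assay, with a stated time of 48 h (a lower number here means a stronger inhibitor, a higher number a weaker inhibitor), the lowest of the three numbers shown. Compound 1 `O=C(/C=C/c1cccc(NC(=O)c2ccccc2Cl)c1)c1nc2ccccc2[nH]1` gives 4570 nM, and the step of a 1.0-fold lower number from compound 1 to compound 2 (0.00 log units; within the scatter) lies within the scatter, so the two cannot be told apart. Compound 3 `Cc1ccc(C(=O)Nc2cccc(/C=C/C(=O)c3nc4ccccc4[nH]3)c2)cc1` gives 9690 nM, and the step of a 2.1-fold higher number from compound 2 to compound 3 (0.33 log units; beyond the scatter) is a modest weakening; the step of a 2.1-fold higher number from compound 1 to compound 3 (0.33 log units; beyond the scatter) reads the same way.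

Compound 4 `Cc1cc(C)cc(C(=O)Nc2cccc(/C=C/C(=O)c3nc4ccccc4[nH]3)c2)c1` has not yet been measured. The change from compound 2 is 3,5-dimethylphenyl in place of 2-bromophenyl on a carbonyl carbon. The step that bears on it is a 2.1-fold higher number from compound 2 to compound 3 (0.33 log units; beyond the scatter), where a methyl-bearing phenyl also displaced the halogenated phenyl and the number rose modestly. For the measured compounds named here, a second methyl has no precedent here, so the size is uncertain, but a modest rise is expected in this assay, roughly a 1.9-fold higher number from compound 2 to compound 4 (0.27 log units; within the scatter). Compound 4 is therefore estimated at 8500 nM, with a range from 4000 nM to 18000 nM.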

Compound 4, half-maximal inhibitory concentration: 24600 nM
Compound 4: middle estimate off by 2.9-fold (0.46 log units), on the low side, and the stated range ends below it.
By their numbers in this assay, from the lowest: compounds 2 and 1 (each within the scatter of the next); then compound 3; then compound 4.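

In this assay, the new compound extends the trend seen with compound 3: a 5.4-fold higher number from compound 2 to compound 4 (0.74 log units; beyond the scatter) and a 5.4-fold higher number from compound 1 to compound 4 (0.73 log units; beyond the scatter), so both methyl-bearing aryl groups give higher numbers than the two halogenated ones. The position also separates the two methyl-bearing groups, with a 2.5-fold higher number from compound 3 to compound 4 (0.40 log units; beyond the scatter), showing that it responds to the methyl pattern as well as to the loss of halogen. No measurement shown here explains this trend.

Because the halogens and the methyls differ in both identity and placement on the ring, the compounds leave open whether the halogen itself or its placement accounts for the lower numbers. A plain phenyl or a methoxy-bearing phenyl at this carbonyl carbon would remain to be placed in this order.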